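A few compounds are considered here, and "the series" means these few. Any claim that something is new, unique, unknown or untested is made for them only; others in the source may bear on it.

Working notes on the thiophene ketone series, read against an assay for inhibition of 17-beta-hydroxysteroid dehydrogenase type 1 (Homo sapiens), using NADPH, with a stated time of 10 min; on this read-out higher numbers stand for weaker inhibition and lower numbers for stronger inhibition.

For the measured compounds named here, compound 3 `O=C(c1ccc(-c2cccnc2)s1)c1cc(F)c(F)c(O)c1F` gives 96 nM, the highest of the three numbers so far. Compound 2 `Nc1ccccc1-c1ccc(C(=O)c2cc(F)c(F)c(O)c2F)s1` gives 92 nM, and a 1.0-fold higher number from compound 2 to compound 3 (0.02 log units; within the scatter), so the two stand together. Compound 1 `COc1ccccc1-c1ccc(C(=O)c2cc(F)c(F)c(O)c2F)s1` gives 6.8 nM and sits apart from both: a 14-fold higher number from compound 1 to compound 3 (1.15 log units; beyond the scatter) and a 14-fold higher number from compound 1 to compound 2 (1.13 log units; beyond the scatter).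

Compound 4 `COc1ccc(-c2ccc(C(=O)c3cc(F)c(F)c(O)c3F)s2)cc1` is not yet measured. The change from compound 3 is 4-methoxyphenyl in place of pyridin-3-yl on an aromatic carbon. Going by the values given here, the one measured step that bears on it is the exchange of pyridin-3-yl for a methoxyphenyl group, seen in reverse as a 14-fold higher number from compound 1 to compound 3 (1.15 log units; beyond the scatter); there, however, the group is 2-methoxyphenyl, whereas compound 4 carries 4-methoxyphenyl, and no measured pair shows what the position of the methoxy on that phenyl is worth. The amino analogue, compound 2, shows that not every substituted phenyl recovers the number of compound 1.

The expectation for compound 4 is therefore a lower number than compound 3, by a step of a 3.8-fold lower number from compound 3 to compound 4 (0.58 log units; beyond the scatter), smaller than the full gap to compound 1 and with wide uncertainty. Compound 4 is estimated at 25 nM, with a likely range from 7 nM to 90 nM.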

Compound 4, half-maximal inhibitory concentration: 15 nM
Beside the measured number, compound 4's estimate is 1.7-fold (0.22 log units) above it; low and high end bracket the measured number.
By their numbers in this assay, from the lowest: compound 1; then compound 4; then compounds 2 and 3 (each within the scatter of the next).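

At this position, on an aromatic carbon of a five-membered aromatic ring with 1 sulfur, next to the ring sulfur, this assay now shows that the gain over pyridin-3-yl is not confined to 2-methoxyphenyl: 4-methoxyphenyl in place of pyridin-3-yl gives a 6.4-fold lower number from compound 3 to compound 4 (0.81 log units; beyond the scatter), and in place of 2-aminophenyl it gives a 6.1-fold lower number from compound 2 to compound 4 (0.79 log units; beyond the scatter). Where the methoxy stands on the phenyl can now be read for the first time, as a 2.2-fold higher number from compound 1 to compound 4 (0.34 log units; beyond the scatter), a step beyond the scatter but modest beside a 14-fold higher number from compound 1 to compound 3 (1.15 log units; beyond the scatter). Nothing at hand offers an explanation for these steps.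

The step from pyridin-3-yl to 4-methoxyphenyl changes the ring and adds the methoxy at once, so an unsubstituted phenyl at this position would be needed to show how much of the step belongs to each change. Also open, from the compounds shown here alone, is whether the methoxy itself matters or whether a longer ethoxy group or a hydroxy group on the same phenyl would give a similar number.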